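This account rests on a few compounds, and the source may have more. Where it says the series, first, only, none or still open, it means among the compounds named here.

Three compounds sharing one core were tested in an ADME assay on THP-1 cells (Homo sapiens) for cytotoxicity; a lower number here means a stronger inhibitor, a higher number a weaker inhibitor. Compound 1 `COc1ccccc1-c1nnc(-c2ccc(C(=O)N/N=C/c3cccc([N+](=O)[O-])c3)cc2)o1` gives 119000 nM, compound 2 `COc1ccccc1-c1nnc(-c2ccc(C(=O)N/N=C/c3ccccc3[N+](=O)[O-])cc2)o1` gives 161000 nM, and compound 3 `COc1ccccc1-c1nnc(-c2ccc(C(=O)N/N=C/c3ccncc3)cc2)o1` gives 173000 nM. Going by the values given here, compound 3 sits alongside the other two: the step of a 1.5-fold higher number from compound 1 to compound 3 (0.16 log units; within the scatter) and the step of a 1.1-fold higher number from compound 2 to compound 3 (0.03 log units; within the scatter) are both within the scatter, as is the step of a 1.4-fold higher number from compound 1 to compound 2 (0.13 log units; within the scatter), so no compound is set apart in this assay.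

Compound 4 `COc1ccccc1-c1nnc(-c2ccc(C(=O)N/N=C/c3ccc(O)cc3O)cc2)o1` has not yet been measured. It differs from compound 3 in one place: 2,4-dihydroxyphenyl in place of pyridin-4-yl on a carbon with a double bond to nitrogen. Among the compounds with values here, none of the measured steps swaps in a group of this kind, so they bear on the question only indirectly, showing that three different groups on that carbon all gave numbers within the scatter of one another in this assay. On that basis no step beyond the scatter is expected, and compound 4 is estimated at 150000 nM, within a range from 70000 nM to 320000 nM, which corresponds to the expected step of a 1.2-fold lower number from compound 3 to compound 4 (0.06 log units; within the scatter).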

Compound 4, half-maximal inhibitory concentration: 104000 nM
Compound 4: the middle estimate sits 1.4-fold (0.16 log units) above what was measured; the measured number falls inside the stated range.
By their numbers in this assay, from the lowest: compounds 4, 1, 2 and 3 (each within the scatter of the next).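

Putting 2,4-dihydroxyphenyl, which brings 2 hydrogen-bond donors where pyridin-4-yl has 0, on the carbon with a double bond to nitrogen stays within the scatter in this assay (a 1.7-fold lower number from compound 3 to compound 4 (0.22 log units; within the scatter)). Going by these compounds alone, the same holds when the new group is set against the two nitrophenyl groups (a 1.5-fold lower number from compound 2 to compound 4 (0.19 log units; within the scatter); a 1.1-fold lower number from compound 1 to compound 4 (0.06 log units; within the scatter)), so a fourth group at this position leaves no compound set apart. Nothing measured here explains why these numbers stay so close.

On these data alone, whether a carboxylic acid or an amine on that ring, or a longer chain in its place, would give a step beyond the scatter remains open. As far as these compounds go, all four compounds also share the same core, so the effect of changing the core itself is unknown, including replacing its methoxy group with a chlorine atom.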